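Working notes: from compound 2 to compound 4

This account rests on a few compounds, and the source may have more. Where it says the series, first, only, none or still open, it means among the compounds named here.

Measured in a functional assay on HepG2 cells (Homo sapiens) for antiproliferative activity, read by MTT assay, with a stated time of 48 h; a lower number here means a stronger inhibitor of growth, a higher number a weaker inhibitor of growth:
- compound 1 `COC(=O)N1N=C(c2ccccc2)CC1c1cc(OC)c(OC)c(OC)c1`: 3950 nM
- compound 2 `COC(=O)N1N=C(c2ccc(OC)cc2)CC1c1cc(OC)c(OC)c(OC)c1`: 1710 nM
- compound 3 `CCOC(=O)N1N=C(c2ccc(OC)cc2)CC1c1cc(OC)c(OC)c(OC)c1`: 9400 nM

Compound 2 has the lowest number of the three, and compound 1 and compound 3 both stand beyond the scatter above it. Compound 4 `CCOc1cccc(C2=NN(C(=O)OC)C(c3cc(OC)c(OC)c(OC)c3)C2)c1` carries 3-ethoxyphenyl in place of 4-methoxyphenyl on a carbon with a double bond to nitrogen. Going by the values given here, no measured compound carries 3-ethoxyphenyl, so the evidence is indirect. At the same place, methoxy in place of hydrogen on an aromatic carbon gave a 2.3-fold lower number from compound 1 to compound 2 (0.36 log units; beyond the scatter). That modest gain was seen with 4-methoxyphenyl, which compound 4 does not carry. Elsewhere in the molecule, methyl in place of hydrogen on a saturated chain carbon bound to an oxygen next to a carbonyl group gave a 5.5-fold higher number from compound 2 to compound 3 (0.74 log units; beyond the scatter), also modest, and that step shows that one added carbon can cost activity in this series. A modest step to a higher number is therefore expected in this assay. The estimated step is a 2.0-fold higher number from compound 2 to compound 4 (0.31 log units; beyond the scatter). For compound 4 the expected value is 3500 nM, with an estimated range of 1300 nM to 9500 nM.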

Compound 4, concentration for 50% growth inhibition: 8360 nM
Compound 4: middle estimate off by 2.4-fold (0.38 log units), on the low side; low and high end bracket the measured number.
By their numbers in this assay, from the lowest: compound 2; then compound 1; then compounds 4 and 3 (each within the scatter of the next).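

In this assay, the gain seen with 4-methoxyphenyl on the carbon with a double bond to nitrogen does not carry over to 3-ethoxyphenyl, which gave a 4.9-fold higher number from compound 2 to compound 4 (0.69 log units; beyond the scatter) and so loses that gain and more. Compared with the unsubstituted phenyl, the ethoxy group gave a 2.1-fold higher number from compound 1 to compound 4 (0.33 log units; beyond the scatter) and thus moved the number the opposite way from the methoxy of compound 2, so an oxygen-linked group on this ring does not lower the number in every case. The data give no reason for this reversal, and 3-ethoxyphenyl differs from 4-methoxyphenyl in both chain and ring place, which these compounds cannot separate.

As far as these compounds go, whether 3-methoxyphenyl or 4-ethoxyphenyl at this place would stand closer to compound 2 or to compound 4 remains open. So does the effect of an amine or a carboxylic acid on this aromatic ring.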